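The compounds below may be only part of what the source reports. "The series", "measured", "known", "first", "only" and "open" are said of these compounds alone.

Measured so far:
compound 1 `Cn1ncc2c(=O)n(-c3ccccc3)c(COc3cccc(F)c3)nc21`, 780 nM
compound 2 `C[C@@H](Sc1nc2c(cnn2C)c(=O)n1-c1ccccc1)c1ccccc1`, 34 nM
compound 3 `CC(Sc1nc2c(cnn2C)c(=O)n1-c1ccccc1)c1cccc(O)c1`, 91 nM

In an assay on isolated protein for inhibition of Retinaldehyde dehydrogenase 3 (Homo sapiens) (on this read-out lower numbers stand for stronger inhibition and higher numbers for weaker inhibition), compound 1 gives 780 nM, the highest of the three numbers; compound 3 with 91 nM and compound 2 with 34 nM both sit well below it, with the gap to compound 2 the wider one.

Compound 4 `Cn1ncc2c(=O)n(-c3ccccc3)c(CNc3cccc(F)c3)nc21` differs from compound 1 in one place: (3-fluorophenyl)amino in place of 3-fluorophenoxy on a saturated chain carbon bound to an aromatic carbon. Going by the values given here, the only step recorded, a 2.7-fold higher number from compound 2 to compound 3 (0.43 log units; beyond the scatter), concerns the aryl group on the sulfur of the thioether pair and leaves the linking atom untouched, so it does not bear on an oxygen-to-nitrogen swap at the chain carbon. Among the compounds with values here, no measured pair covers the change from compound 1 to compound 4. With nothing in the series to point either way, the expectation is a step of no size beyond the scatter in this assay, so that a 1.1-fold lower number from compound 1 to compound 4 (0.05 log units; within the scatter) is taken as essentially flat. Compound 4 is therefore estimated at 700 nM, within the range 250 nM to 2500 nM.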

Compound 4, half-maximal inhibitory concentration in the Retinaldehyde dehydrogenase 3 assay: 1050 nM
Beside the measured number, compound 4's estimate is 1.5-fold (0.18 log units) below it; the measured number falls inside the stated range.
By their numbers in the Retinaldehyde dehydrogenase 3 assay, from the lowest: compound 2; then compound 3; then compounds 1 and 4 (each within the scatter of the next).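

In the Retinaldehyde dehydrogenase 3 assay, the swap on the saturated chain carbon leaves compound 1 and compound 4 level: a 1.3-fold higher number from compound 1 to compound 4 (0.13 log units; within the scatter). The same swap does separate them in a physicochemical assay for solubility, using the shake flask method, in phosphate buffer, with a stated time of 24 h, at pH 7.4 (a lower number here means a less soluble compound, a higher number a more soluble compound), where compound 1 gives 194000 nM and compound 4 gives 64000 nM, and compound 4 is the less soluble of the two: the measured solubility of compound 1, 194000 nM, and of compound 4, 64000 nM, a 3.0-fold lower number (0.48 log units; beyond the scatter) The hydrogen-bond donor that enters with (3-fluorophenyl)amino therefore has no readable counterpart in the Retinaldehyde dehydrogenase 3 assay, so this pair shows a change at this position that registers in one read-out and not in the other.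

Compounds 2 and 3 differ from compound 1 and compound 4 in more than one place. No comparison of the link itself can be read from them. From the compounds shown here alone, whether a methylated amine or an amide at this chain carbon would track compound 1 or compound 4 in the Retinaldehyde dehydrogenase 3 assay and in the physicochemical assay remains open.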